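Sulfonyl aryl change on a chloroquinoline core

A few compounds are considered here, and "the series" means these few. Any claim that something is new, unique, unknown or untested is made for them only; others in the source may bear on it.

The series shares a core in which an aryl sulfonyl group sits on an aromatic carbon. Compound 1 `CC1CCN(c2c(S(=O)(=O)c3ccccc3)cnc3ccc(Cl)cc23)CC1` carries phenyl on the sulfonyl sulfur, and in an assay on isolated protein for displacement of a labelled ligand from metabotropic glutamate receptor 5 (Homo sapiens), with a stated time of 60 min, tested at 1 uM (on this read-out lower numbers stand for less inhibition and higher numbers for more inhibition at the one concentration tested (going by the name of the read-out)), compound 1 gives 59%. Compound 2 `Cc1cc(C)cc(S(=O)(=O)c2cnc3ccc(Cl)cc3c2N2CCC(C)CC2)c1` carries 3,5-dimethylphenyl there, and in this assay compound 2 gives 49%. Going by the values given here, the only step measured so far, a number 10 percentage points lower from compound 1 to compound 2 (within the scatter), lies within the scatter, so compound 2 has the lower of the two numbers in this assay only on paper; nothing separates it from compound 1.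

Compound 3 `CC1CCN(c2c(S(=O)(=O)c3cccc(C#N)c3)cnc3ccc(Cl)cc23)CC1` differs from compound 2 by 3-cyanophenyl in place of 3,5-dimethylphenyl on a sulfonyl sulfur. Among the compounds with values here, the step from compound 1 to compound 2 is the one measurement that bears on a change of the aryl group on the sulfonyl sulfur, and it stayed within the scatter. Within the data shown here, no measured step speaks to a 3-cyanophenyl group itself, so the expectation rests on that single step alone.

Compound 3 is therefore expected to give 52% in this assay, between 32% and 70%. The expected step from compound 2 is a number 3 percentage points higher from compound 2 to compound 3 (within the scatter), a change not beyond the scatter.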

Compound 3, a percentage reported as inhibition, at one concentration (the size of the read-out at that concentration, not a potency): 90%
Compound 3: middle estimate off by 38 percentage points, on the low side; measured number outside the range, above it.
By their numbers in this assay, from the lowest: compounds 2 and 1 (each within the scatter of the next); then compound 3.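

Going by these compounds alone, the aryl group on the sulfonyl sulfur proves able to carry a large change in this assay: 3-cyanophenyl in place of 3,5-dimethylphenyl gives a number 41 percentage points higher from compound 2 to compound 3 (beyond the scatter), whereas the one earlier step at this place stayed within the scatter. Measured against the plain phenyl of compound 1, cyano in place of hydrogen on an aromatic carbon gives a number 31 percentage points higher from compound 1 to compound 3 (beyond the scatter), so the large rise does not depend on comparison with the 3,5-dimethylphenyl group alone, and compound 3 stands highest of the three, clear of both others. Nothing measured here accounts for this rise.

The compounds shown leave open whether the high number belongs to the nitrile itself or would also appear with a methoxy group, a trifluoromethyl group or a carboxamide on the same aryl ring. They also leave open how compound 3 would behave across a range of concentrations, since a single-concentration inhibition figure is not a potency, and whether the nitrile would give a comparable number with an amine other than the one on the shared core.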